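Working notes: from compound 2 to compound 3

A few compounds are considered here, and "the series" means these few. Any claim that something is new, unique, unknown or untested is made for them only; others in the source may bear on it.

Two compounds of the series have numbers in a functional assay on PC-3 cells (Homo sapiens) for inhibition, read by MTT assay, with a stated time of 72 h; a higher number here means a weaker inhibitor, a lower number a stronger inhibitor. Compound 1, `COc1cccc(NC(=O)CSc2nc(Nc3ccccc3)c3ccccc3n2)c1`, gives 11600 nM. Compound 2, `C=CC(=O)Nc1cccc(NC(=O)CSc2nc(Nc3ccccc3C)c3ccccc3n2)c1`, gives 23200 nM. Compound 2 carries the highest of the two numbers, and its nearest neighbour is compound 1, whose number sits lower by a margin that stays within the usual scatter, so no order between the two can be read from these figures. Going by the values given here, no pair of measured compounds differs in a single place, so no measured step stands behind the series yet.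

Compound 3, `C=CC(=O)Nc1cccc(NC(=O)CSc2nc(Nc3ccc(Cl)cc3Cl)c3ccccc3n2)c1`, has not been measured in this assay. It differs from compound 2 in one place:
2,4-dichlorophenyl in place of 2-methylphenyl on a nitrogen on an aromatic ring
Nothing measured shows how this change acts on the number. Among the compounds with values here, the expected step, a 1.5-fold lower number from compound 2 to compound 3 (0.16 log units; within the scatter), is none beyond the scatter in either direction, as no measured pair offers a basis for a larger shift. Compound 3 is accordingly estimated at 16000 nM in this assay, with a range from 5000 nM to 50000 nM.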

Compound 3, half-maximal inhibitory concentration: 25700 nM
Estimate against measurement, compound 3: 1.6-fold (0.21 log units) below; measured number inside the range.
By their numbers in this assay, from the lowest: compounds 1, 2 and 3 (each within the scatter of the next, the first and the last beyond it).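

In this assay, the series now has its first measured step, at the place on a nitrogen on an aromatic ring: 2,4-dichlorophenyl in place of 2-methylphenyl gives a 1.1-fold higher number from compound 2 to compound 3 (0.04 log units; within the scatter) and stays within the scatter. A group of 7 carbon atoms has thus been exchanged for one of 8 heavy atoms, 2 of them chlorine, without the read-out separating compound 2 from compound 3, so this pair shows that this particular change leaves no measurable mark at this place. Nothing measured on these compounds bears on a cause for this result.

As far as these compounds go, it remains open whether an amine or a carboxylic acid on this aromatic ring, or a longer alkyl chain on the same nitrogen in place of the ring, would shift the number beyond the scatter. Compound 1 and compound 2 differ in more than one place, so the acrylamide and methoxy groups cannot yet be compared, and what either contributes to the number remains unresolved.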